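The source may report more compounds than this note shows. Statements on the series, on what has been measured and on what is new or still open speak of the compounds shown alone.

Compound 1 `Nc1cc(N)c2nc(-c3ccccc3)c(NCc3ccc(Cl)c(Cl)c3)nc2c1` gives 13500 nM in a functional assay on OVCAR-8 cells (Homo sapiens) for inhibition, read by sulforhodamine B assay, with a stated time of 48 h; a lower number here means a stronger inhibitor of growth, a higher number a weaker inhibitor of growth.
Compound 2 `COc1ccc(CNc2nc3cc(N)cc(N)c3nc2-c2ccccc2)cc1OC` gives 33900 nM in this assay.
Compound 3 `Nc1cc(N)c2nc(-c3ccccc3)c(NCc3ccc(F)cc3)nc2c1` gives 6030 nM in this assay.

Compound 3 has the lowest number of the three, and both of its gaps lie beyond the scatter: a 2.2-fold lower number from compound 1 to compound 3 (0.35 log units; beyond the scatter) and a 5.6-fold lower number from compound 2 to compound 3 (0.75 log units; beyond the scatter). On these numbers compound 3 is therefore the strongest inhibitor of growth of the set.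

Compound 4 `COc1ccc(CNc2nc3cc(N)cc(N)c3nc2-c2ccccc2)cc1` differs from compound 3 in one place: methoxy in place of fluoro on an aromatic carbon. For the measured compounds named here, two measured steps bear on this change. a 2.5-fold higher number from compound 1 to compound 2 (0.40 log units; beyond the scatter) shows that methoxy groups in place of chlorines went with a higher number, and a 5.6-fold lower number from compound 2 to compound 3 (0.75 log units; beyond the scatter) shows that a fluoro in place of methoxy groups went with a lower number. Both point the same way, so the number for compound 4 in this assay is expected to rise by a modest amount, with the expected step being a 2.5-fold higher number from compound 3 to compound 4 (0.40 log units; beyond the scatter). Compound 4 is estimated at 15000 nM, with a range from 6000 nM to 40000 nM.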

Compound 4, concentration for total growth inhibition: 39800 nM
For compound 4 the middle estimate is 2.7-fold (0.42 log units) below the measured one; the measured number falls inside the stated range.
By their numbers in this assay, from the lowest: compound 3; then compound 1; then compounds 2 and 4 (each within the scatter of the next).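

In this assay, for the compounds shown here, methoxy in place of fluoro on the aromatic carbon para to a large group gives a 6.6-fold higher number from compound 3 to compound 4 (0.82 log units; beyond the scatter), so this single swap, with no other change, separates the lowest number so far from the highest group. Compound 2 carries a second methoxy that compound 4 lacks, yet the step shows a 1.2-fold higher number from compound 2 to compound 4 (0.07 log units; within the scatter), so the high number stays when only the 4-methoxyphenyl remains, and the single methoxy still sits apart from the chlorinated compound, with a 2.9-fold higher number from compound 1 to compound 4 (0.47 log units; beyond the scatter). No measurement here explains why these groups differ.

Going by these compounds, it remains open how a hydroxyl, an amine or a plain hydrogen on this carbon would compare with fluoro and methoxy. On these data alone, a longer chain between the ring and the nitrogen also remains untested within these compounds.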